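The source may hold more compounds than are shown below. What is called first, only, known or untested is meant among the compounds shown, and "the series" means these compounds.

Compound 1 `O=C(N/N=C/c1c(-c2cc3ccccc3oc2=O)[nH]c2ccccc12)c1cccc(Br)c1` is the reference point of the series. In a toxicity assay on Vero cells (Chlorocebus sabaeus) for inhibition, read by MTT assay, with a stated time of 48 h (a higher number here means a weaker inhibitor, a lower number a stronger inhibitor), compound 1 gives > 200000 nM, which is a limit of the assay and not a number. For the measured compounds named here, its single measured neighbour, compound 2 `O=C(N/N=C/c1c(-c2cc3ccccc3oc2=O)[nH]c2ccccc12)c1ccc(Cl)cc1F`, carries 4-chloro-2-fluorophenyl in place of 3-bromophenyl on the carbonyl carbon. In this assay compound 2 gives > 200000 nM, again a limit of the assay. The step that the two limits leave unreadable from compound 1 to compound 2 therefore cannot be read in size or direction; what remains is the limit of > 200000 nM in this assay, at which 2 of the 2 values shown sit.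

Compound 3 `O=C(N/N=C/c1c(-c2cc3ccc(Br)cc3oc2=O)[nH]c2ccccc12)c1cccc(Br)c1` differs from compound 1 by bromo in place of hydrogen on an aromatic carbon. Going by the values given here, no measured step touches this position on the shared core, so the only evidence bearing on compound 3 is the pair above, where variation at the carbonyl carbon left both values at the limit. Nothing in these data points to a readable gain in inhibition from the added bromo. For compound 3 in this assay the estimate is 200000 nM, with a range from 100000 nM to 400000 nM. The expected step of a number no higher from compound 1 to compound 3 (the limit leaves the size open) is thus none beyond the scatter, most likely reported once more as a limit only.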

Compound 3, half-maximal inhibitory concentration: > 200000 nM
Compound 3 gave a limit, no number; the forecaster's own chance of this, stated with the estimate: 75%; the middle value sits exactly at the limit.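

For the compounds shown here, compound 3 and compound 1 both stand at a limit of the assay, not a number, so no step between them can be read in this assay: the limit of > 200000 nM in this assay, at which 3 of the 3 values shown sit. The compounds shown leave open whether any change to the shared core, at the carbonyl carbon or the aromatic carbon carrying bromo, gives a readable value in this assay.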